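From 3-nitrophenyl to 4-methoxyphenyl on the amide-type nitrogen

The source may report more compounds than this note shows. Statements on the series, on what has been measured and on what is new or still open speak of the compounds shown alone.

Among the compounds with values here, in a functional assay on HCT-116 cells (Homo sapiens) for inhibition, read by MTT assay, with a stated time of 2 days (on this read-out lower numbers stand for stronger inhibition of growth and higher numbers for weaker inhibition of growth), compound 2 (`Nc1ccccc1NC(=O)CCCNCC(=O)Nc1cccc([N+](=O)[O-])c1`) gives 900 nM and holds the lowest of the three numbers so far. Compound 1 (`Nc1ccccc1NC(=O)CCCNCC(=O)Nc1ccc(Br)cc1`) gives 7700 nM and compound 3 (`COc1ccc(NC(=O)CNc2ccc(C(=O)Nc3ccccc3N)cc2)cc1`) gives 7500 nM on a different core. The next structure is compound 4 (`COc1ccc(NC(=O)CNCCCC(=O)Nc2ccccc2N)cc1`), reached through 4-methoxyphenyl in place of 3-nitrophenyl on an amide-type nitrogen with 4-methoxyphenyl in place of 3-nitrophenyl on an amide-type nitrogen. Within the data shown here, one measured step bears directly on this position: an 8.6-fold lower number from compound 1 to compound 2 (0.93 log units; beyond the scatter) came with 3-nitrophenyl in place of 4-bromophenyl and lies beyond the scatter. Compound 4 gives up the 3-nitrophenyl, so that step, read backwards, suggests a higher number. Compound 3 also carries 4-methoxyphenyl and stands at 7500 nM but does not share the core, so it is only a loose guide. A rise somewhat smaller than the measured step is expected, and the estimated change is a 4.4-fold higher number from compound 2 to compound 4 (0.65 log units; beyond the scatter) in this assay and beyond the scatter. For compound 4 the estimate is 4000 nM (expected range 1500 nM to 10000 nM).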

Compound 4, concentration for 50% growth inhibition: 8600 nM
Compound 4: middle estimate off by 2.2-fold (0.33 log units), on the low side; measured number inside the range.
By their numbers in this assay, from the lowest: compound 2; then compounds 3, 1 and 4 (each within the scatter of the next).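

In this assay, the change from 3-nitrophenyl to 4-methoxyphenyl on the amide-type nitrogen gives a 9.6-fold higher number from compound 2 to compound 4 (0.98 log units; beyond the scatter), so the low number of compound 2 is lost on the shared core. Methoxy in place of bromo on an aromatic carbon gives a 1.1-fold higher number from compound 1 to compound 4 (0.05 log units; within the scatter), which places 4-methoxyphenyl and 4-bromophenyl level on this core and leaves 3-nitrophenyl as the only group of the three that stands apart. Nothing at hand explains why 3-nitrophenyl stands apart at this position.

Still open, on these data alone, is whether the lower number follows the nitro group itself or where it sits, a question that 4-nitrophenyl and 3-methoxyphenyl on the same nitrogen would address. Also open, as far as these compounds go, is whether 3-aminophenyl or 3-carboxyphenyl there would match compound 2.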